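The compounds below may be only part of what the source reports. "The series", "measured", "known", "first", "only" and "open" are said of these compounds alone.

Notes on the series, step from compound 3 to compound 4.

Compound 3 `CC(C)Sc1nnc(-c2c(CN3CCC(N4CCCC4)CC3)c3ccccc3n2C)n1-c1ccccc1` stands highest of the three measured compounds in a physicochemical assay for lipophilicity (a lower number here means a more polar compound, a higher number a more lipophilic compound), giving 5.16. Compound 1 `CC(C)Sc1nnc(-c2c(CNC3CC3)c3ccccc3n2C)n1-c1ccccc1` gives 4.81 in this assay, and compound 2 `CC(C)Sc1nnc(-c2c(CNc3cnccn3)c3ccccc3n2C)n1-c1ccccc1` gives 4.22. The measured steps were a number 0.35 log units higher from compound 1 to compound 3 (beyond the scatter), a number 0.94 log units higher from compound 2 to compound 3 (beyond the scatter) and a number 0.59 log units lower from compound 1 to compound 2 (beyond the scatter).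

Compound 4 `CC(C)Sc1nnc(-c2c(CNCCN3CCCC3)c3ccccc3n2C)n1-c1ccccc1` carries the change ((2-(pyrrolidin-1-yl)ethyl)amino in place of 4-(pyrrolidin-1-yl)piperidin-1-yl on a saturated chain carbon bound to an aromatic carbon). This reverses part of what happened from compound 1 to compound 3: the group that enters once again has one hydrogen-bond donor, as cyclopropylamino had, and is smaller than the group that leaves by the count given, while keeping one five-membered ring with one hetero atom. For the measured compounds named here, the steps that bear on it are therefore the one from compound 1 to compound 3 and, more loosely, the one from compound 2 to compound 3, both upward and both modest; the move to compound 4 is expected to run the other way.

The expected step is a number 0.56 log units lower from compound 3 to compound 4 (beyond the scatter), a modest decrease beyond the scatter. Compound 4 is estimated at 4.6 in this assay, within a range of 4 to 5.2.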

Compound 4, partition coefficient: 4.83
For compound 4 the middle estimate is 0.23 log units below the measured one, within the range that was stated.
By their numbers in this assay, from the lowest: compound 2; then compounds 1 and 4 (each within the scatter of the next); then compound 3.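

On the saturated chain carbon bound to an aromatic carbon, (2-(pyrrolidin-1-yl)ethyl)amino in place of 4-(pyrrolidin-1-yl)piperidin-1-yl gives a number 0.33 log units lower from compound 3 to compound 4 (beyond the scatter) in this assay, so opening up the larger group while retaining the pyrrolidine ring gives a step of modest size. On the amine nitrogen, 2-(pyrrolidin-1-yl)ethyl in place of cyclopropyl gives a number 0.02 log units higher from compound 1 to compound 4 (within the scatter), which means that these two substituents, different as they are in make-up, cannot be told apart in this assay. In place of pyrazin-2-yl, the same substituent gives a number 0.61 log units higher from compound 2 to compound 4 (beyond the scatter), so among the three substituents on the amine nitrogen, pyrazin-2-yl is the one that stands apart, with cyclopropyl and 2-(pyrrolidin-1-yl)ethyl both beyond the scatter from it.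

On these data alone, it stays open whether a morpholine ring in place of the pyrrolidine ring, a longer chain on the amine nitrogen or a methyl on that nitrogen would keep the number level with cyclopropyl or shift it. The compounds shown come with no measurement that explains any of these steps.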